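This account rests on a few compounds, and the source may have more. Where it says the series, first, only, none or still open, it means among the compounds named here.

The series shares one core, seen in compound 1 `CC1=CC[C@H](C(C)C)c2cc(C)c(OC(=O)c3ccc(C)cc3)cc21`, compound 2 `CC1=CC[C@H](C(C)C)c2cc(C)c(OC(=O)Nc3ccccc3)cc21` and compound 3 `CC1=CC[C@H](C(C)C)c2cc(C)c(OC(=O)c3cccc(C(F)(F)F)c3)cc21`, and the three differ only in the group carried on the carbonyl carbon. In a functional assay on SK-LU-1 cells (Homo sapiens) for antiproliferative activity, read by sulforhodamine B assay, with a stated time of 48 h, tested at 50 uM (on this read-out lower numbers stand for less inhibition and higher numbers for more inhibition at the one concentration tested (going by the name of the read-out)), compound 1 gives 85.4%. In this assay compound 2 gives 100%. In this assay compound 3 gives 18.3%, the lowest of the three numbers and beyond the scatter from each of the others. Among the compounds with values here, the only step measured between compounds that differ in one place, a number 14.6 percentage points higher from compound 1 to compound 2 (beyond the scatter), concerns a different exchange and does not bear on the change now at hand. Compound 4 `CC1=CC[C@H](C(C)C)c2cc(C)c(OC(=O)c3cccc(C)c3)cc21` has not been measured. It differs from compound 3 in one place: methyl in place of trifluoromethyl on an aromatic carbon. Within the data shown here, no measured pair shows this exchange, so no step speaks to it directly; what the numbers do show is that compound 1, carrying a methyl on its six-membered aromatic ring, stands far higher than compound 3, which carries a trifluoromethyl there. Taking that as the only pointer, compound 4 is expected to show a number 51.7 percentage points higher from compound 3 to compound 4 (beyond the scatter). The estimate for compound 4 in this assay is 70%, within a range from 35% to 95%.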

Compound 4, a percentage reported as inhibition, at one concentration (the size of the read-out at that concentration, not a potency): "not active" (no number reported)
Nothing numeric was reported for compound 4, and the estimate cannot be compared.
By their numbers in this assay, from the lowest: compound 3; then compound 1; then compound 2.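

In this assay, within the data shown here, compound 4 is reported as not active, with no number given, so no step from compound 3 to compound 4 can be read. The compounds shown leave open how far methyl in place of trifluoromethyl on the aromatic carbon shifts inhibition in this series. No supporting evidence at hand explains this result.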